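Ring-closed amidine side chain on a pyrazole aldehyde scaffold

The source may hold more compounds than are shown below. What is called first, only, known or untested is meant among the compounds shown, and "the series" means these compounds.

Measured compounds:
- Compound 1 `CN(C)/C=N/c1c(C=O)c(-c2ccccc2)nn1-c1ccccc1` — 9300 nM
- Compound 2 `CCN(/C=N/c1c(C=O)c(-c2ccccc2)nn1-c1ccccc1)CC` — 30500 nM

Both compounds share one core, and they differ only in the amine attached to the carbon with a double bond to nitrogen. In a functional assay on NPC-TW01 cells (Homo sapiens) for inhibition, read by MTT assay, with a stated time of 72 h (on this read-out higher numbers stand for weaker inhibition of growth and lower numbers for stronger inhibition of growth), compound 1 gives 9300 nM. In this assay compound 2 gives 30500 nM, the highest number of the two, so compound 2 is the weaker inhibitor of growth in this pair; the step is a 3.3-fold higher number from compound 1 to compound 2 (0.52 log units; beyond the scatter), a modest worsening on moving from dimethylamino to diethylamino.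

Compound 3 `O=Cc1c(-c2ccccc2)nn(-c2ccccc2)c1/N=C/N1CCCC1` has not yet been measured. It differs from compound 2 by pyrrolidin-1-yl in place of diethylamino on a carbon with a double bond to nitrogen. Going by the values given here, the only step that bears on this change is the one from compound 1 to compound 2, where a somewhat larger acyclic amine gave a modestly higher number. Among the compounds with values here, a ring of the same size as diethylamino may sit anywhere between the two measured values, and there is no measured pair that shows the effect of closing such a ring. The expected step of a 1.9-fold lower number from compound 2 to compound 3 (0.28 log units; within the scatter) is therefore small and uncertain, perhaps slightly downward. Compound 3 is expected to give about 16000 nM in this assay, with a range from 6000 nM to 42000 nM.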

Compound 3, concentration for 50% growth inhibition: > 50000 nM
Compound 3 was reported as a limit; the forecaster's own chance of this, stated with the estimate: 15%; middle value at least 3.1-fold (0.49 log units) from the limit.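

In this assay compound 3 is reported only as a limit: the limit of > 50000 nM in this assay, at which 1 of the 3 values shown sits. Closing the open diethylamino group into the pyrrolidin-1-yl ring, with the same count of heavy atoms, gives no sign of a gain in growth inhibition, but the step reads an at least 1.6-fold higher number from compound 2 to compound 3 (0.21 log units; that floor lies within the scatter), so no order between these two compounds can be claimed. The firmer finding comes from the comparison with the smallest amine, which gives an at least 5.3-fold higher number from compound 1 to compound 3 (0.73 log units; beyond the scatter); together with a 3.3-fold higher number from compound 1 to compound 2 (0.52 log units; beyond the scatter), this shows that on the carbon with a double bond to nitrogen, dimethylamino gives the lowest number of the three, whether the larger group is open or ring-closed.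

How far compound 3 really lies beyond compound 2 stays unknown, and these compounds give no reason for the loss of growth inhibition seen on moving away from dimethylamino. Nor do they show whether a six-membered ring such as piperidin-1-yl or morpholin-4-yl, or a smaller ring such as azetidin-1-yl, would follow compound 3 or come closer to compound 1.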